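The source may report more compounds than this note shows. Statements on the series, on what has been measured and on what is new or still open speak of the compounds shown alone.

Compound 1 `CCc1ccc(N(CC(C)C)S(=O)(=O)c2ccc3c(c2)C(=O)CC(C(C)C2CCOCC2)O3)cc1` — 4.93
Compound 2 `CCc1ccc(N(CC(C)C)S(=O)(=O)c2ccc(OCC3CCOCC3)c3c2CCC3=O)cc1` — 4.44
Compound 3 `Cc1ccc(NS(=O)(=O)c2ccc3c(c2)C(=O)CC(C2CCOCC2)O3)c(C)c1` — 2.75

In a physicochemical assay for lipophilicity, at pH 7.4 (on this read-out higher numbers stand for higher lipophilicity and lower numbers for lower lipophilicity), compound 1 stands highest of the three numbers. Its nearest neighbour is compound 2, which gives 4.44, a gap beyond the scatter; furthest away is compound 3, which gives 2.75, a gap well beyond the scatter.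

Compound 4 `CCc1ccc(N(CC(C)C)S(=O)(=O)c2ccc3c(c2)C(=O)CC(C2CCNCC2)O3)cc1` has not yet been measured in this assay. It differs from compound 1 in one place: piperidin-4-yl in place of 1-(oxan-4-yl)ethyl on a saturated ring carbon. Among the compounds with values here, no step between two measured compounds that differ in exactly this way exists, so the size of the change can only be expected, not read off. The change leaves an ether ring and a two-carbon branch and brings in a ring with a hydrogen-bond donor; on this kind of read-out such a swap is expected to push the number down, and not by a small amount.

Compound 4 is therefore expected to come out at 2, within 1 to 3. The step this estimate means, a number 2.93 log units lower from compound 1 to compound 4 (beyond the scatter), is expected to lie clearly beyond the scatter.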

Compound 4, distribution coefficient: 2.21
For compound 4 the middle estimate is 0.21 log units below the measured one; the measured number falls inside the stated range.
By their numbers in this assay, from the lowest: compound 4; then compound 3; then compound 2; then compound 1.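

In this assay the saturated ring carbon next to the ring oxygen proves highly sensitive to its substituent: with the rest of compound 1 unchanged, piperidin-4-yl in place of 1-(oxan-4-yl)ethyl gives a number 2.72 log units lower from compound 1 to compound 4 (beyond the scatter), the first step read at this position. The earlier compounds shown here differed from each other in more than one place, so they could not isolate any contribution from this substituent. No measurement shown here accounts for the size of the step.

The step changes the ring hetero atom and removes the ethyl link together, so the compounds shown leave open how much each part contributes. An oxan-4-yl group on the same carbon, or 1-(piperidin-4-yl)ethyl, with the rest of compound 1 kept, would divide the step between those two parts.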